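This account rests on a few compounds, and the source may have more. Where it says the series, first, only, none or still open, it means among the compounds named here.

Notes on the series built on the shared core of compound 1 `Cc1cc(C)c(NC(=O)N(Cc2ccc(N3CCN(C)CC3)cc2)C2CCCCCC2)c(C)c1`, varied at one aromatic carbon of the six-membered carbon ring, para to a large group. In a functional assay on a cell-free system (plasma) with sterol O-acyltransferase, Soat (Rattus norvegicus) as the target (a higher number here means that more compound is needed for the effect, a lower number that less compound is needed), compound 1 reports only the limit > 1 mg/kg. Compound 2 `Cc1cc(C)c(NC(=O)N(Cc2ccc(-c3cccs3)cc2)C2CCCCCC2)c(C)c1` gives 0.28 mg/kg in this assay. Compound 3 `Cc1cc(C)c(NC(=O)N(Cc2ccc(-n3cccn3)cc2)C2CCCCCC2)c(C)c1` in this assay likewise reports only the limit > 1 mg/kg. Compound 3 therefore stands at the limit of > 1 mg/kg in this assay, at which 2 of the 3 values shown sit. The readable steps are an at least 3.5-fold lower number from compound 1 to compound 2 (0.55 log units; beyond the scatter) and an at least 3.5-fold higher number from compound 2 to compound 3 (0.55 log units; beyond the scatter); the remaining pair is a step that the two limits leave unreadable from compound 1 to compound 3.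

Compound 4 `Cc1cc(C)c(NC(=O)N(Cc2ccc(-c3ccnn3C)cc2)C2CCCCCC2)c(C)c1` differs from compound 3 in one place: 1-methyl-1H-pyrazol-5-yl in place of 1H-pyrazol-1-yl on an aromatic carbon. The step that bears on this is an at least 3.5-fold higher number from compound 2 to compound 3 (0.55 log units; beyond the scatter), in which a carbon-linked five-membered ring gave a number while the nitrogen-linked 1H-pyrazol-1-yl gave only a limit. The entering 1-methyl-1H-pyrazol-5-yl is again carbon-linked, so some recovery is expected, though the data do not settle its size. The step of an at least 1.2-fold lower number from compound 3 to compound 4 (0.09 log units; that floor lies within the scatter) is the expected outcome. Compound 4 is estimated at 0.8 mg/kg, within 0.3 mg/kg to 2.5 mg/kg.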

Compound 4, dose for half-maximal effect: < 1 mg/kg
Compound 4 gave a limit, no number (the forecaster's own chance of this, stated with the estimate: 45%); the middle value is on the limit's open side.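

In this assay compound 4 reports a limit (< 1 mg/kg) and not a number, and it is the only compound shown with a limit of this sign: the limit of < 1 mg/kg in this assay, at which 1 of the 4 values shown sits. At this aromatic carbon, para to a large group, 1-methyl-1H-pyrazol-5-yl gives a number no higher from compound 3 to compound 4 (the limit leaves the size open) and a number no higher from compound 1 to compound 4 (the limit leaves the size open) as well. A five-membered aromatic ring with 2 hetero atoms is therefore not confined to the upper limit at this position, as the 1H-pyrazol-1-yl of compound 3 alone might have suggested.

The sizes of these steps cannot be read, nor can the step between compound 2 and compound 4, and the carbon link and the added methyl of compound 4 are not separated by the compounds shown. Going by these compounds, how a plain phenyl ring or a carboxylic acid at this carbon would read in this assay also stays open.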